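The source may report more compounds than this note shows. Statements on the series, on what has been measured and on what is new or still open speak of the compounds shown alone.

Measured set in a functional assay on MDA-MB-231 cells (Homo sapiens) for antiproliferative activity, read by MTT assay, with a stated time of 48 h; a lower number here means a stronger inhibitor, a higher number a weaker inhibitor:
compound 1, `CS(=O)(=O)c1ccc(Nc2ncc(F)c(Nc3nc4ccccc4s3)n2)cc1`, gives 4980 nM
compound 2, `Cc1cnc(Nc2ccc(S(C)(=O)=O)cc2)nc1Nc1nc2ccccc2s1`, gives 14800 nM
compound 3, `NS(=O)(=O)c1ccc(Nc2nccc(Nc3nc4ccc(F)cc4s3)n2)cc1`, gives 1800 nM

Compound 3 sits lowest of the three; its nearest neighbour is compound 1, and compound 2 lies furthest from it. Both of those gaps are beyond the scatter.

Within the data shown here, the one step measured within one place is a 3.0-fold higher number from compound 1 to compound 2 (0.47 log units; beyond the scatter), the change being (methyl in place of fluoro on an aromatic carbon). The difference between the core of compound 1 and the core of compound 3 is not broken down here.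

Compound 4, `Cc1ccc2nc(Nc3ccnc(Nc4ccc(S(N)(=O)=O)cc4)n3)sc2c1`, is not yet measured in this assay. It arises from compound 3 by methyl in place of fluoro on an aromatic carbon. This is the same kind of change as that from compound 1 to compound 2, but the place is not the same: there it was on a six-membered aromatic ring with 2 nitrogen, ortho to a large group, two atoms from the ring nitrogen, para to a large group; here it is on a six-membered aromatic ring of carbon only, part of a fused system of two rings, meta and para to a fused ring.

Because the measured step of a 3.0-fold higher number from compound 1 to compound 2 (0.47 log units; beyond the scatter) gave a modest weakening, a step of similar direction but uncertain size is expected for compound 4, namely a 1.9-fold higher number from compound 3 to compound 4 (0.29 log units; within the scatter). Compound 4 is estimated at 3500 nM in this assay, with a likely range from 1500 nM to 9000 nM.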

Compound 4, half-maximal inhibitory concentration: 3870 nM
Beside the measured number, compound 4's estimate is 1.1-fold (0.04 log units) below it; low and high end bracket the measured number.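

In this assay the exchange of fluoro for methyl recurs on a second core, with a 2.2-fold higher number from compound 3 to compound 4 (0.33 log units; beyond the scatter), and this step runs the same way as the earlier one, with no difference in size that can be told apart: the same change on two cores in this assay, a 3.0-fold higher number (0.47 log units; beyond the scatter) from compound 1 to compound 2 and a 2.2-fold higher number (0.33 log units; beyond the scatter) from compound 3 to compound 4, 1.4-fold (0.14 log units) apart, within the scatter of two such steps. On these two cores the change therefore carries over in direction and roughly in size, although in compound 3 and compound 4 it sits on a six-membered aromatic ring of carbon only, part of a fused system, and in compound 1 and compound 2 on a ring with 2 nitrogen. Two steps do not show that it would hold on a further core, and they do not separate the effect of the ring carrying the group from that of the other differences between the cores.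

The steps shown exchange only fluoro and methyl, so it remains open whether chloro, methoxy or a nitrile at these places would fit the same trend. As far as these compounds go, how an amine or a carboxylic acid there would read in this assay is also open.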